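Notes on the thiourea aryl substituent swap

The compounds below may be only part of what the source reports. "The series", "measured", "known", "first", "only" and "open" are said of these compounds alone.

Measured in a functional assay on MKN-74 cells (Homo sapiens) for antiproliferative activity, with a stated time of 24 h; a higher number here means a weaker inhibitor, a lower number a stronger inhibitor:
compound 1, `NC(=O)c1c(NC(=O)c2ccccc2Cl)sc2c1CCN(Cc1cc(Cl)cc(Cl)c1)C2`: 23700 nM
compound 2, `NC(=O)c1c(NC(=O)c2ccccc2Cl)sc2c1CCN(C(=S)Nc1ccccc1I)C2`: 2630 nM

Going by the values given here, compound 2 stands lowest of the two numbers in this assay; the one measured step, a 9.0-fold lower number from compound 1 to compound 2 (0.95 log units; beyond the scatter), is the only gap known. Compound 3, `COc1ccccc1NC(=S)N1CCc2c(sc(NC(=O)c3ccccc3Cl)c2C(N)=O)C1`, differs from compound 2 by methoxy in place of iodo on an aromatic carbon. Among the compounds with values here, no measured step touches this aryl ring: the step of a 9.0-fold lower number from compound 1 to compound 2 (0.95 log units; beyond the scatter) exchanges the whole group on the ring amine nitrogen and so does not bear on the change. With nothing in the data to point either way, no shift beyond the scatter is expected. Compound 3 is therefore estimated at 3500 nM (range 1000 nM to 12000 nM), an expected step of a 1.3-fold higher number from compound 2 to compound 3 (0.12 log units; within the scatter).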

Compound 3, half-maximal inhibitory concentration: 35200 nM
The estimate for compound 3 lay 10-fold (1.00 log units) below the measured number; measured number outside the range, above it.
By their numbers in this assay, from the lowest: compound 2; then compounds 1 and 3 (each within the scatter of the next).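

In this assay the aryl carbon ortho to a large group proves sensitive to the substituent: methoxy in place of iodo gives a 13-fold higher number from compound 2 to compound 3 (1.13 log units; beyond the scatter). With a 1.5-fold higher number from compound 1 to compound 3 (0.17 log units; within the scatter), the thiourea on the ring amine nitrogen does not by itself give the lower number of compound 2, which depends here on the 2-iodophenyl group. No evidence is available to account for this difference.

From the compounds shown here alone, whether bromo, chloro or methyl at this carbon would keep the lower number of compound 2 remains open, as does the effect of iodo elsewhere on the ring.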